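The source may hold more compounds than are shown below. What is called first, only, known or untested is meant among the compounds shown, and "the series" means these compounds.

Measured compounds in an assay on L cells for inhibition of Protein-serine O-palmitoleoyltransferase porcupine (Mus musculus), read by reporter gene assay, with a stated time of 24 h; on this read-out lower numbers stand for an effect already at smaller amounts and higher numbers for an effect only at larger amounts of compound:
Compound 1, `COc1ccc2nc(NC(=O)CNC(=O)c3nn(-c4ccccc4)c(=O)c4ccccc34)sc2c1`, gives 210 nM in this assay.
Compound 2, `O=C(CSc1nc2c(c(=O)n1-c1ccccc1)SCC2)Nc1ccc(-c2ccsc2)cn1`, gives 2 nM in this assay.
Compound 3, `O=C(CSc1nc2c(c(=O)n1-c1ccccc1)SCC2)Nc1ncc(-c2ccco2)cn1`, gives 3.5 nM in this assay.

Compound 2 and compound 3 lie within the usual scatter of each other, so nothing separates them on these numbers. Compound 1, which has a different core, stands beyond the scatter with a much higher number than compound 2. Compound 2 therefore sits at the low end of the three numbers, together with compound 3.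

For the measured compounds named here, compound 4, `O=C(CSc1nc2c(c(=O)n1-c1ccccc1)SCC2)Nc1ccc(-c2ccoc2)cn1`, keeps the core of compound 2 and changes only one group: furan-3-yl in place of thiophen-3-yl on an aromatic carbon. The two groups are of the same size and ring type, differing only in the hetero atom. Going by the values given here, no measured pair shows the effect of such a swap here, so the expectation rests on the closeness of the two groups alone. The step from compound 2 to compound 4 is expected to be small, a 1.5-fold higher number from compound 2 to compound 4 (0.18 log units; within the scatter), and not beyond the scatter. For compound 4 the estimate in this assay is 3 nM, within a range from 1 nM to 10 nM.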

Compound 4, half-maximal effective concentration: 1.5 nM
Estimate against measurement, compound 4: 2.0-fold (0.30 log units) above; the measured number falls inside the stated range.
By their numbers in this assay, from the lowest: compounds 4, 2 and 3 (each within the scatter of the next, the first and the last beyond it); then compound 1.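

In this assay, for the compounds shown here, putting furan-3-yl in place of thiophen-3-yl gives a 1.3-fold lower number from compound 2 to compound 4 (0.12 log units; within the scatter), the first direct comparison in this set of two compounds that differ in one place. At this position on the six-membered aromatic ring with one nitrogen, exchanging the sulfur of the five-membered aromatic ring for oxygen therefore leaves the read-out unchanged within the usual scatter. Nothing available here explains why the two rings read alike.

The compounds shown leave open whether this position accepts anything other than a five-membered aromatic ring, such as a phenyl ring, an amine or a carboxylic acid. A single pair also cannot show whether the same exchange would read alike on a different core, such as that of compound 1.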